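The source may hold more compounds than are shown below. What is called first, only, known or untested is meant among the compounds shown, and "the series" means these compounds.

Measured compounds, with their numbers in an assay on CHO cells for displacement of a labelled ligand from Alpha-1A adrenergic receptor (Homo sapiens); a lower number here means a stronger inhibitor, a higher number a weaker inhibitor:
compound 1, `COc1cccc(OC)c1OCCNCCOc1ccccc1OCc1ccccc1Cl`: 1.41 nM
compound 2, `COc1cccc(OC)c1OCCNCCOc1ccccc1OCc1ccc(Cl)cc1`: 0.251 nM
compound 3, `COc1cccc(OC)c1OCCNCCOc1ccccc1OCc1cccc(C)c1`: 0.398 nM

Compound 1 has the highest number of the three, so it is the weakest of the three in this assay: the step of a 5.6-fold lower number from compound 1 to compound 2 (0.75 log units; beyond the scatter) and the step of a 3.5-fold lower number from compound 1 to compound 3 (0.55 log units; beyond the scatter) both lie beyond the scatter, while compound 2 and compound 3 differ by a 1.6-fold higher number from compound 2 to compound 3 (0.20 log units; within the scatter), which is within the scatter.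

Compound 4, `COc1ccccc1COc1ccccc1OCCNCCOc1c(OC)cccc1OC`, is not yet measured. It differs from compound 1 in one place: methoxy in place of chloro on an aromatic carbon. The measured steps all alter the same benzyl group, but none of them exchanges the chloro for a methoxy; they move the chloro or replace it with a methyl elsewhere on the ring, and each lowers the number by a modest amount. They therefore bear only loosely on this change. Since compound 1 is the weakest and the other variants of this ring all gave lower numbers, a small to modest drop in this assay is expected, with wide uncertainty.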

Compound 4, inhibition constant: 2 nM
Beside the measured number, compound 4's estimate is 2.5-fold (0.40 log units) below it; the range from low to high includes it.
By their numbers in this assay, from the lowest: compounds 2 and 3 (each within the scatter of the next); then compounds 1 and 4 (each within the scatter of the next).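

In this assay, methoxy in place of chloro on this aromatic carbon, ortho to a large group, gives no change that can be told from the scatter, with a 1.4-fold higher number from compound 1 to compound 4 (0.15 log units; within the scatter). The 2-methoxyphenyl compound therefore stays apart from the other two ring variants, just as the 2-chlorophenyl compound does, with a 5.0-fold higher number from compound 3 to compound 4 (0.70 log units; beyond the scatter) and an 8.0-fold higher number from compound 2 to compound 4 (0.90 log units; beyond the scatter), so among these four compounds both groups in the 2-substituted form give higher numbers than 3-methylphenyl and 4-chlorophenyl. Nothing shown here explains this pattern.

As far as these compounds go, it remains open whether an unsubstituted phenyl or a 2-methylphenyl would group with compound 1 and compound 4 or with compound 2 and compound 3. A 4-methoxyphenyl would also help, since the steps from compound 2 and compound 3 change the group and its ring position together.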